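Hydroxy Placement on the Phenyl Ring of Compound 1

The compounds below may be only part of what the source reports. "The series", "measured", "known", "first", "only" and "open" are said of these compounds alone.

Compound 1 `C#CCSc1nc(Nc2ccccc2)c2ccncc2n1`: 29400 nM in a functional assay on HepG2 cells (Homo sapiens) for inhibition, read by MTT assay, with a stated time of 72 h; on this read-out lower numbers stand for stronger inhibition and higher numbers for weaker inhibition
Compound 2 `C#CCSc1nc(Nc2ccccc2O)c2ccncc2n1`: > 80000 nM in this assay

Among the compounds with values here, compound 1 gives the only number among the values shown; compound 2 reports only a limit of this assay, (the limit of > 80000 nM in this assay, at which 1 of the 2 values shown sits). The step from compound 1 to compound 2 is therefore a limit as well, an at least 2.7-fold higher number from compound 1 to compound 2 (0.43 log units; beyond the scatter).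

Compound 3 `C#CCSc1nc(Nc2cccc(O)c2)c2ccncc2n1` is not yet measured. It differs from compound 1 by hydroxy in place of hydrogen on an aromatic carbon. Within the data shown here, the one measured step that bears on this change is the step to compound 2, which placed the same group elsewhere on the same ring and weakened inhibition at least modestly. From that step alone, compound 3 is expected to follow the same direction, with an estimated step of a 2.4-fold higher number from compound 1 to compound 3 (0.38 log units; beyond the scatter). The estimate for compound 3 in this assay is 70000 nM, within a range from 30000 nM to 160000 nM, with a real chance that only a limit is reported.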

Compound 3, half-maximal inhibitory concentration: 29500 nM
For compound 3 the middle estimate is 2.4-fold (0.38 log units) above the measured one; the measured number lies below the stated range.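

In this assay, hydroxy in place of hydrogen on the phenyl ring does not by itself weaken inhibition: as 3-hydroxyphenyl, meta to a large group, it gives a step within the scatter (a 1.0-fold higher number from compound 1 to compound 3 (0.00 log units; within the scatter)). The loss seen earlier therefore belongs to 2-hydroxyphenyl and does not extend to every hydroxy placement on this ring, and exchanging that group for 3-hydroxyphenyl gives a clear difference (an at least 2.7-fold lower number from compound 2 to compound 3 (0.43 log units; beyond the scatter)). The size of that second step remains a minimum, since it rests on a limit: the limit of > 80000 nM in this assay, at which 1 of the 3 values shown sits.

The compounds shown leave open whether an amine or a carboxylic acid in the place of this hydroxy would also stay within the scatter of compound 1. They also do not tell how a methoxy group would read at either placement on the ring.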